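Acetoxy to hydroxy: working notes on compound 4

A few compounds are considered here, and "the series" means these few. Any claim that something is new, unique, unknown or untested is made for them only; others in the source may bear on it.

Measured so far in an ADME assay on HEK293 cells (Homo sapiens) for cytotoxicity, read by MTT assay, with a stated time of 72 h; on this read-out lower numbers stand for stronger inhibition and higher numbers for weaker inhibition:
- compound 1 `C=CCOc1cc(C2=C(c3cc(OC)c(OC)c(OC)c3)C(=O)C(O)C2)ccc1OC` gives > 100 ug/mL, a limit of the assay
- compound 2 `COc1ccc(C2=C(c3cc(OC)c(OC)c(OC)c3)C(=O)C(O)C2)cc1` gives 6.3 ug/mL
- compound 3 `COc1ccc(C2=C(c3cc(OC)c(OC)c(OC)c3)C(=O)C(OC(C)=O)C2)cc1F` gives 59 ug/mL

Of the two actual numbers, compound 2 at 6.3 ug/mL lies lower and compound 3 at 59 ug/mL is the higher, with the gap beyond the scatter. The remaining entry, for compound 1, is a limit and not a number.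

Compound 4 `COc1ccc(C2=C(c3cc(OC)c(OC)c(OC)c3)C(=O)C(O)C2)cc1F` is still unmeasured. Relative to compound 3 the change is hydrogen in place of acetyl on an oxygen on a saturated carbon, or acetoxy to hydroxy.

Among the measured compounds shown here, the only measured single-place step is an at least 15-fold lower number from compound 1 to compound 2 (1.20 log units; beyond the scatter). Its size rests on (the limit of > 100 ug/mL in this assay, at which 1 of the 3 values shown sits). That step concerns an aromatic carbon and not this oxygen, so it gives no direct size for the present change.

The closest guide is compound 2 at 6.3 ug/mL, which carries the hydroxy of compound 4 but lacks the fluorine. A clear move towards that number is therefore expected, without reaching it with any certainty. The expected change in this assay is a 4.9-fold lower number from compound 3 to compound 4 (0.69 log units; beyond the scatter). For compound 4 the estimated value is 12 ug/mL, with an expected range of 4 ug/mL to 40 ug/mL.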

Compound 4, half-maximal inhibitory concentration: > 100 ug/mL
Compound 4 was reported as a limit; the forecaster's own chance of this, stated with the estimate: 3%; at least 8.3-fold (0.92 log units) between middle value and limit.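

In this assay the change from acetoxy to hydroxy on this oxygen gives an at least 1.6-fold higher number from compound 3 to compound 4 (0.22 log units; that floor lies within the scatter); that floor alone does not establish a rise. Even so, the fluoro series shows no fall towards the lower number of compound 2 at 6.3 ug/mL. With the hydroxy held constant, fluoro in place of hydrogen on an aromatic carbon gives an at least 15-fold higher number from compound 2 to compound 4 (1.20 log units; beyond the scatter), so in the compounds shown the hydroxy does not carry the low value of compound 2 by itself, and the effect of this change depends on the aromatic substituent present. The entry for compound 4 is a limit and not a number, and the step from compound 1, whose entry is also a limit, cannot be read, so both sizes stay bounded by the same ceiling: the limit of > 100 ug/mL in this assay, at which 2 of the 4 values shown sit.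

From the compounds shown here alone, it remains open how far the true value of compound 4 lies from that of compound 3, and so whether the acetoxy to hydroxy change has any real size in the fluoro series. Also open, going by these compounds, is how this assay would read with chloro in place of the fluoro, or with an amine or a carboxylic acid in place of the hydroxy.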